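Swapping the Sulfonyl Substituent on Compound 1

The source may hold more compounds than are shown below. What is called first, only, known or untested is meant among the compounds shown, and "the series" means these compounds.

- compound 1 `Cc1ccc(S(=O)(=O)/C(=C/c2ccc(O)c([N+](=O)[O-])c2)C(=O)c2ccc(Cl)cc2)cc1`: 25000 nM
- compound 2 `Cc1ccc(S(=O)(=O)/C(=C/c2sccc2C)C(=O)c2ccc(Cl)cc2)cc1`: 10000 nM
- compound 3 `Cc1ccc(S(=O)(=O)/C(=C/c2ccc(Cl)cc2)C(=O)c2ccc(Cl)cc2)cc1`: 1000 nM

All three values come from a functional assay on DU-145 cells (Homo sapiens) for inhibition, read by trypan blue exclusion, with a stated time of 96 h; on this read-out lower numbers stand for stronger inhibition of growth and higher numbers for weaker inhibition of growth. Compound 1 has the highest number of the three, which makes it the weakest growth inhibitor in this small set. Both of its steps to the other compounds lie beyond the scatter.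

Compound 4 `O=C(/C(=C\c1ccc(O)c([N+](=O)[O-])c1)S(=O)(=O)Cc1ccccc1Cl)c1ccc(Cl)cc1` keeps the core of compound 1 and changes one group: 2-chlorobenzyl in place of 4-methylphenyl on a sulfonyl sulfur. In words, 2-chlorobenzyl stands in place of 4-methylphenyl on a sulfonyl sulfur.

For the measured compounds named here, no measured step touches that sulfonyl sulfur. The steps of a 2.5-fold lower number from compound 1 to compound 2 (0.40 log units; beyond the scatter), a 25-fold lower number from compound 1 to compound 3 (1.40 log units; beyond the scatter) and a 10-fold lower number from compound 2 to compound 3 (1.00 log units; beyond the scatter) all change the group on the double-bonded chain carbon instead, and they range from modest to large. They show that numbers in this set can move a long way, but they give no direction for a change made elsewhere. The best expectation in this assay is therefore no step beyond the scatter, with real uncertainty on both sides.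

The estimate amounts to a 1.3-fold lower number from compound 1 to compound 4 (0.10 log units; within the scatter), an expected step within the scatter. For compound 4 the expected value is 20000 nM, with an estimated range from 4000 nM to 70000 nM.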

Compound 4, concentration for 50% growth inhibition: 10000 nM
Estimate against measurement, compound 4: 2.0-fold (0.30 log units) above; the range from low to high includes it.
By their numbers in this assay, from the lowest: compound 3; then compounds 2 and 4 (each within the scatter of the next); then compound 1.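

The sulfonyl sulfur turns out to be a place where the number can move: in this assay, 2-chlorobenzyl in place of 4-methylphenyl gives a 2.5-fold lower number from compound 1 to compound 4 (0.40 log units; beyond the scatter) and so reaches beyond the scatter, although this is a smaller move than a 25-fold lower number from compound 1 to compound 3 (1.40 log units; beyond the scatter) made on the double-bonded chain carbon. The swap alters several things at once, since the entering group brings a chlorine and the leaving group takes away a methyl, so this single step cannot show which of these differences matters. Nothing measured here explains why the number moved.

Going by these compounds, it remains open whether a plain benzyl group without the chlorine, or a small alkyl chain such as ethyl, on the sulfonyl sulfur would give a similar number, which would help separate the contribution of the chlorine from that of the rest of the group. On these data alone, it also remains open whether 2-chlorobenzyl would lower the number to a similar extent on compound 3, which carries 4-chlorophenyl on the double-bonded chain carbon.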